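The compounds below may be only part of what the source reports. "The series", "measured", "known", "first", "only" and "open" are said of these compounds alone.

Measured so far:
`COc1ccc(OC)c(NC(=O)Nc2nn(-c3ccccc3)c(=O)c3ccccc23)c1` compound 1, 8.25 nM in a functional assay on CHO cells for antagonist activity at adenosine receptor A3 (Homo sapiens), read by cAMP accumulation, with a stated time of 15 min; a lower number here means a stronger inhibitor, a higher number a weaker inhibitor
`COc1ccc(NC(=O)Nc2nn(-c3ccccc3)c(=O)c3ccccc23)cc1` compound 2, 28 nM in this assay

Among these two numbers compound 2 gives the higher one; the only comparable step is a 3.4-fold higher number from compound 1 to compound 2 (0.53 log units; beyond the scatter). Compound 3 `O=C(NCc1ccccc1)Nc1nn(-c2ccccc2)c(=O)c2ccccc12` differs from compound 2 by benzyl in place of 4-methoxyphenyl on an amide-type nitrogen. Within the data shown here, no measured step covers a benzyl group here; the single step of a 3.4-fold higher number from compound 1 to compound 2 (0.53 log units; beyond the scatter) shows only that trimming the aryl group raised the number modestly. A weakening beyond the scatter is therefore expected, though its size is uncertain. For compound 3 the estimate is 80 nM, between 20 nM and 400 nM, a step of a 2.9-fold higher number from compound 2 to compound 3 (0.46 log units; beyond the scatter).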

Compound 3, half-maximal inhibitory concentration: 1.15 nM
Beside the measured number, compound 3's estimate is 70-fold (1.84 log units) above it; the whole stated range lies above it.
By their numbers in this assay, from the lowest: compound 3; then compound 1; then compound 2.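

Benzyl on this amide-type nitrogen gives a 24-fold lower number from compound 2 to compound 3 (1.39 log units; beyond the scatter) and also a 7.2-fold lower number from compound 1 to compound 3 (0.86 log units; beyond the scatter) in the same direction, so an aryl group attached directly to this nitrogen is not required for a low number. Removing a methoxy group raised the number in the earlier step, yet benzyl, which has no methoxy group, gives the lowest number of the three, so methoxy count alone does not order these compounds. On these data alone, whether a longer chain such as phenethyl, or a benzyl group carrying methoxy, would lower the number further remains open. Nothing measured here explains the gain from benzyl.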